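The compounds below may be only part of what the source reports. "The series", "measured", "known", "first", "only" and "open" are said of these compounds alone.

Measured so far in a functional assay on MDA-MB-231 cells (Homo sapiens) for cytotoxicity, read by MTT assay, with a stated time of 48 h; a higher number here means a weaker inhibitor, a lower number a stronger inhibitor:

- compound 1, `Cc1ccccc1Cn1cc(COc2ccc3c(=O)ccoc3c2)nn1`: > 100000 nM
- compound 2, `O=c1ccoc2cc(OCc3cn(Cc4ccccc4Cl)nn3)ccc12`: 15100 nM
- compound 3, `CC(C)(C)c1ccc(Cn2cc(COc3ccc4c(=O)ccoc4c3)nn2)cc1`: > 100000 nM

Compound 3 stands at the limit of this assay; its value is a limit, not a number, and it shares that position with compound 1 (the limit of > 100000 nM in this assay, at which 2 of the 3 values shown sit). Within the data shown here, compound 2 is the only compound of the three with a numeric value in this assay.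

The next compound is compound 4, `O=c1ccoc2cc(OCc3cn(Cc4ccc([N+](=O)[O-])cc4)nn3)ccc12`. It differs from compound 3 by nitro in place of tert-butyl on an aromatic carbon.

Among the measured compounds shown here, only one measured step bears on this change: an at least 6.6-fold lower number from compound 1 to compound 2 (0.82 log units; beyond the scatter), which also exchanges one substituent on an aromatic carbon of the same ring and moves the value off the limit by an at least modest amount. The exchange from tert-butyl to nitro is a different pair of groups, so that step is a loose guide only. The expectation in this assay is therefore a step of similar size, toward a lower number, with a real chance that compound 4 still returns only a limit.

For compound 4 the expected value is 50000 nM, with a range of 8000 nM to 200000 nM. The step this estimate implies, an at least 2.0-fold lower number from compound 3 to compound 4 (0.30 log units; that floor lies within the scatter), is an expectation, not a measurement.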

Compound 4, half-maximal inhibitory concentration: 71300 nM
The estimate for compound 4 lay 1.4-fold (0.15 log units) below the measured number; measured number inside the range.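

A substituent para to a large group now gives a number in this assay, yet the exchange of tert-butyl for nitro is only an at least 1.4-fold lower number from compound 3 to compound 4 (0.14 log units; that floor lies within the scatter), and the comparison with the 2-methylphenyl compound is no firmer at an at least 1.4-fold lower number from compound 1 to compound 4 (0.14 log units; that floor lies within the scatter). The change from 2-chlorophenyl to 4-nitrophenyl is a clearer result, at a 4.7-fold higher number from compound 2 to compound 4 (0.67 log units; beyond the scatter), which shows that leaving the limit does not by itself bring a compound level with compound 2. Compound 1 and compound 3 each stay at a limit rather than a number, so the first two steps give floors and not true sizes: the limit of > 100000 nM in this assay, at which 2 of the 4 values shown sit.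

Open, as far as these compounds go, is whether the difference between compound 2 and compound 4 follows the group or its place on the ring, and a 4-chlorophenyl compound would bear directly on that. Also open, from the compounds shown here alone, is how an amine or a carboxylic acid on the same aromatic carbon would read in this assay.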